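Lengthening a Side Chain on the Ring Carbon

The compounds below may be only part of what the source reports. "The series", "measured", "known", "first", "only" and "open" are said of these compounds alone.

Of the compounds shown here, three sharing one core have been measured in a functional assay on A549 cells (Homo sapiens) for cytotoxicity, read by MTT assay, with a stated time of 48 h; on this read-out lower numbers stand for stronger inhibition and higher numbers for weaker inhibition. Compound 3 `Cc1ccc(S(=O)(=O)N2CC2(C)CO[C@@H]2O[C@@H]3CO[C@H](c4ccccc4)O[C@@H]3[C@H](OCc3ccccc3)[C@H]2OCc2ccccc2)cc1` gives 153000 nM, the lower of the two plain numbers. Compound 1 `CCCCCCCCCCCCCCC1(CO[C@@H]2O[C@@H]3CO[C@H](c4ccccc4)O[C@@H]3[C@H](OCc3ccccc3)[C@H]2OCc2ccccc2)CN1S(=O)(=O)c1ccc(C)cc1`, which carries a longer chain on the same ring carbon, gives 1000000 nM, a weaker result beyond the scatter. Compound 2 `Cc1ccc(S(=O)(=O)N2C(CO[C@@H]3O[C@@H]4CO[C@H](c5ccccc5)O[C@@H]4[C@H](OCc4ccccc4)[C@H]3OCc3ccccc3)C2(C)C)cc1` reaches only a limit of the assay, > 1000000 nM, as noted in the limit of > 1000000 nM in this assay, at which 1 of the 3 values shown sits. Compound 4 `CCCCCCCCCC1(CO[C@@H]2O[C@@H]3CO[C@H](c4ccccc4)O[C@@H]3[C@H](OCc3ccccc3)[C@H]2OCc2ccccc2)CN1S(=O)(=O)c1ccc(C)cc1` differs from compound 3 by octyl in place of hydrogen on a saturated chain carbon bound to a saturated ring carbon. Since the long chain of compound 1 gave 1000000 nM, the nonyl chain of compound 4 is expected to weaken activity, with a step of a 2.6-fold higher number from compound 3 to compound 4 (0.42 log units; beyond the scatter) beyond the scatter. Compound 4 is estimated at 400000 nM, likely between 120000 nM and 1000000 nM.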

Compound 4, half-maximal inhibitory concentration: 154000 nM
Beside the measured number, compound 4's estimate is 2.6-fold (0.41 log units) above it; measured number inside the range.
By their numbers in this assay, from the lowest: compounds 3 and 4 (each within the scatter of the next); then compound 1.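

Methyl and nonyl on this saturated ring carbon read alike, so a chain of this length costs nothing here: a 1.0-fold higher number from compound 3 to compound 4 (0.00 log units; within the scatter). The weaker number appears only with the still longer chain, as taking off its pentyl shows: a 6.5-fold lower number from compound 1 to compound 4 (0.81 log units; beyond the scatter). Nothing measured here accounts for this difference.

Open, from the compounds shown here alone, is how a hexyl or a dodecyl chain would read at this position, and so where along the chain the weakening sets in. Also open, going by these compounds, is whether a chain ending in an amine or a carboxylic acid would read differently.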